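Inverting One Stereocentre on the Saturated Ring

This account rests on a few compounds, and the source may have more. Where it says the series, first, only, none or still open, it means among the compounds named here.

In an assay for inhibition of Indoleamine 2,3-dioxygenase 1 (Homo sapiens), with stated times of 10 min and 60 min, tested at 100 uM (on this read-out higher numbers stand for a stronger effect at the one concentration tested and lower numbers for a weaker effect), compound 2 `FC(F)(F)c1cc(NC[C@@H]2CCCCN2)c2cn[nH]c2c1` gives 81%, the smaller of the two numbers recorded, though the gap to compound 1 `FC(F)(F)c1cc(NC[C@H]2CCCN2)c2cn[nH]c2c1`, which gives 83%, lies within the scatter. For the measured compounds named here, the single measured step, a number 2 percentage points lower from compound 1 to compound 2 (within the scatter), swaps one saturated ring for another and leaves the read-out essentially where it was. Compound 3 `FC(F)(F)c1cc(NC[C@H]2CCCCN2)c2cn[nH]c2c1` has not yet been measured; it differs from compound 2 as follows: the two compounds have the same atoms and bonds and differ only in configuration as drawn: 1 of 1 stereo elements differ; a stereocentre at a saturated ring carbon is drawn S in compound 2 and R in compound 3. Going by the values given here, no measured pair concerns a change of configuration alone, so that step gives no guidance on direction; the two measured compounds show only that both ring sizes sit high. Compound 3 is therefore expected to stay near its neighbour, while allowing for a loss, with an expected step of a number 9 percentage points lower from compound 2 to compound 3 (within the scatter). The estimate for compound 3 is 72%, ranging from 40% to 90%.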

Compound 3, a percentage reported as inhibition, at one concentration (the size of the read-out at that concentration, not a potency): 69%
Beside the measured number, compound 3's estimate is 3 percentage points above it, within the range that was stated.
By their numbers in this assay, from the lowest: compound 3; then compounds 2 and 1 (each within the scatter of the next).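

Inverting the stereocentre at the saturated ring carbon produces a number 12 percentage points lower from compound 2 to compound 3 (beyond the scatter), the first step in this assay to lie beyond the scatter, so this position responds to configuration in a way that the change of ring size between the first two compounds did not reveal. Piperidin-2-yl in place of pyrrolidin-2-yl also stops being a neutral swap when the ring carbon is drawn R, giving a number 14 percentage points lower from compound 1 to compound 3 (beyond the scatter). The loss can be assigned to the stereocentre alone, because nothing else separates the pair: the fact that compounds 2 and 3 differ only in the configuration as drawn.

As far as these compounds go, whether the pyrrolidin-2-yl compound responds to inversion in the same way remains open. So does whether a morpholin-3-yl ring in place of piperidin-2-yl would hold the number of compound 2, and each of these numbers comes from a single concentration and is not a potency.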